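The source may report more compounds than this note shows. Statements on the series, on what has been measured and on what is new or still open speak of the compounds shown alone.

Measured so far:
Compound 1, `O=C(OCc1ccccc1)N1CCN(C(=S)SCc2cn(Cc3ccc(Cl)cc3)nn2)CC1`, in a functional assay on MGC-803 cells (Homo sapiens) for inhibition, read by MTT assay, with a stated time of 72 h (on this read-out higher numbers stand for weaker inhibition and lower numbers for stronger inhibition), gives 31300 nM.
Compound 2, `Cc1ccc(Cn2cc(CSC(=S)N3CCN(C(=O)OCc4ccccc4)CC3)nn2)cc1`, in this assay gives 9370 nM.
Compound 3, `S=C(SCc1cn(Cc2ccc(Cl)cc2)nn1)N1CCNCC1`, in this assay gives "not determined" (no result reported).

Compound 2 differs from compound 1 by methyl in place of chloro on an aromatic carbon. That change gave a 3.3-fold lower number from compound 1 to compound 2 (0.52 log units; beyond the scatter). Compound 4, `Cc1ccc(Cn2cc(CSC(=S)N3CCNCC3)nn2)cc1`, has not yet been measured; it differs from compound 3 by methyl in place of chloro on an aromatic carbon, the same change as before, at the same place. Compound 3 in turn differs from compound 1 by hydrogen in place of benzyloxycarbonyl on an amine nitrogen in a ring, so the two pairs share everything except this change at the ring nitrogen. Compound 3 has no number. Within the data shown here, the size of the step from compound 3 to compound 4 cannot be anchored on its own pair; the only guide is the step seen from compound 1 to compound 2 in this assay, which was modest. Among the measured compounds shown here, it is therefore expected that compound 4 lands near compound 2, with wide uncertainty, since a core with hydrogen at the ring nitrogen has no measured example here. The estimate for compound 4 in this assay is 10000 nM, expected between 2000 nM and 50000 nM.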

Compound 4, half-maximal inhibitory concentration: 64300 nM
Compound 4: middle estimate off by 6.4-fold (0.81 log units), on the low side; the whole stated range lies below it.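

In this assay, hydrogen in place of benzyloxycarbonyl on the ring nitrogen gives a 6.9-fold higher number from compound 2 to compound 4 (0.84 log units; beyond the scatter), a modest step beyond the usual scatter, so with the methyl group in place, compound 4 is the weaker inhibitor of the pair. Chloro to methyl gave a 3.3-fold lower number from compound 1 to compound 2 (0.52 log units; beyond the scatter) on the core carrying benzyloxycarbonyl, but compound 3 has no number, so the matching step to compound 4 cannot be read, and whether the change carries over to the core with hydrogen at that nitrogen remains unshown. Nothing measured here accounts for the rise in the number when benzyloxycarbonyl is replaced by hydrogen.

On these data alone, it remains open whether a smaller group on the ring nitrogen, such as acetyl or methyl, would read closer to compound 2 or to compound 4 in this assay. Also open, as far as these compounds go, is how fluoro or methoxy, in the place held by chloro and methyl, would read on either core.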